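Methyl on a Ring Amine: Expected Inhibition of Compound 4

The source may hold more compounds than are shown below. What is called first, only, known or untested is meant among the compounds shown, and "the series" means these compounds.

Compound 1 `Clc1ccc(Oc2ccc3nc(-c4ccc(OC5CCNCC5)cc4)oc3c2)cc1` shows 20.6% in an assay on isolated protein for inhibition of advanced glycosylation end product-specific receptor (Homo sapiens), read by FRET, with stated times of 30 min and 1 h, tested at 4 uM; a lower number here means less inhibition, a higher number more inhibition at the concentration tested (going by the name of the read-out). Compound 2 `CN1CCC(Oc2ccc(-c3nc4ccc(Oc5ccc(Cl)cc5)cc4o3)cc2)CC1` differs from compound 1 by methyl in place of hydrogen on an amine nitrogen in a ring, and in this assay compound 2 gives 19.5%, a step of a number 1.1 percentage points lower from compound 1 to compound 2 (within the scatter). Compound 3 `Clc1ccc(Oc2ccc3nc(-c4ccc(OCCCN5CCNCC5)cc4)oc3c2)cc1` differs from compound 1 by 3-(piperazin-1-yl)propyl in place of piperidin-4-yl on an oxygen on an aromatic ring; in this assay compound 3 gives 42.7%, reached through a number 22.1 percentage points higher from compound 1 to compound 3 (beyond the scatter) and a number 23.2 percentage points higher from compound 2 to compound 3 (beyond the scatter), so compound 3 stands highest of the three measured.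

Compound 4 `CN1CCN(CCCOc2ccc(-c3nc4ccc(Oc5ccc(Cl)cc5)cc4o3)cc2)CC1` differs from compound 3 by methyl in place of hydrogen on an amine nitrogen in a ring. This is the same kind of change as that from compound 1 to compound 2, but not the same: there the methyl entered on a six-membered non-aromatic ring with 1 nitrogen, three ring bonds from the ring atom that bears a large group, whereas here the ring has 2 nitrogen and the methyl sits three ring bonds from the ring nitrogen.

Because the earlier step was a number 1.1 percentage points lower from compound 1 to compound 2 (within the scatter), compound 4 is expected to lie close to compound 3, with an estimated step of a number 2.7 percentage points lower from compound 3 to compound 4 (within the scatter). Compound 4 is therefore estimated at 40%, expected between 28% and 52%.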

Compound 4, a percentage reported as inhibition, at one concentration (the size of the read-out at that concentration, not a potency): 24.3%
For compound 4 the middle estimate is 15.7 percentage points above the measured one, outside the stated range (below it).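

In this assay the methyl change on the piperazine nitrogen gives a number 18.4 percentage points lower from compound 3 to compound 4 (beyond the scatter), and the other two new steps are a number 4.8 percentage points higher from compound 2 to compound 4 (within the scatter) and a number 3.7 percentage points higher from compound 1 to compound 4 (within the scatter), so the higher reading of compound 3 does not persist once that nitrogen carries methyl. The same methyl change therefore cannot be carried from one core to the other as a fixed step in this series: the same change on two cores in this assay, a number 1.1 percentage points lower (within the scatter) from compound 1 to compound 2 and a number 18.4 percentage points lower (beyond the scatter) from compound 3 to compound 4, 17.3 percentage points apart, beyond the scatter of two such steps. Going by these compounds alone, this rests on only two pairs, read at a single concentration, and it shows neither why the two steps part nor how the change would behave on any further core.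

The compounds shown leave open whether ethyl or acetyl on that piperazine nitrogen would behave as methyl does. They also leave open whether a shorter chain, 2-(piperazin-1-yl)ethyl on the oxygen, would keep the reading of compound 3 and lose it again on methylation.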